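This account rests on a few compounds, and the source may have more. Where it says the series, first, only, none or still open, it means among the compounds named here.

In a functional assay on PC-3 cells (Homo sapiens) for inhibition, read by sulforhodamine B assay, with a stated time of 72 h (on this read-out lower numbers stand for stronger inhibition and higher numbers for weaker inhibition), compound 1 `Nc1sc(-c2ccc(Cl)cc2)c(-c2ccc(Cl)cc2)c1C(=O)N1CCCCC1=O` gives 4940 nM, compound 2 `Nc1sc(-c2ccc(Cl)cc2)c(-c2ccc(Cl)cc2)c1C(=O)NC1CCC(O)CC1` gives 5670 nM, and compound 3 `CC(C)CNC(=O)c1c(N)sc(-c2ccc(Cl)cc2)c1-c1ccc(Cl)cc1` gives 13200 nM. Compound 3 therefore has the highest number of the three and the weakest inhibition.

Compound 4 `Nc1sc(-c2ccc(Cl)cc2)c(-c2ccc(Cl)cc2)c1C(=O)N1CCCC1` keeps the shared core but carries pyrrolidin-1-yl in place of isobutylamino on a carbonyl carbon.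

Among the measured compounds shown here, no measured compound carries pyrrolidin-1-yl, so the evidence is indirect. The closest comparison is the change from the ring 2-oxopiperidin-1-yl to isobutylamino, a 2.7-fold higher number from compound 1 to compound 3 (0.43 log units; beyond the scatter). Replacing 4-hydroxycyclohexyl with isobutyl on the amide-type nitrogen gives a similar result, a 2.3-fold higher number from compound 2 to compound 3 (0.37 log units; beyond the scatter). In both cases, moving to the isobutyl compound raises the number modestly.

Reversing that kind of change suggests a small step towards lower numbers in this assay, possibly no larger than the scatter. The estimated change is a 1.7-fold lower number from compound 3 to compound 4 (0.22 log units; within the scatter). Compound 4 is expected at 8000 nM, with an estimated range of 3000 nM to 20000 nM.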

Compound 4, half-maximal inhibitory concentration: 6220 nM
The estimate for compound 4 lay 1.3-fold (0.11 log units) above the measured number, within the range that was stated.
By their numbers in this assay, from the lowest: compounds 1, 2 and 4 (each within the scatter of the next); then compound 3.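

In this assay the swap of isobutylamino for pyrrolidin-1-yl on the carbonyl carbon gives a 2.1-fold lower number from compound 3 to compound 4 (0.33 log units; beyond the scatter) with the same count of heavy atoms, so a ring in place of an open chain, together with the loss of the amide hydrogen, is enough to shift this read-out modestly. The other two steps, a 1.1-fold higher number from compound 2 to compound 4 (0.04 log units; within the scatter) and a 1.3-fold higher number from compound 1 to compound 4 (0.10 log units; within the scatter), lie within the scatter, so compound 4 cannot be ranked against compound 1 or compound 2, even though compound 2 keeps an amide hydrogen and compound 4 has none. No measurement here explains why the swap changes the number.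

The compounds shown leave open whether the ring or the missing amide hydrogen matters more. Diethylamino, which lacks both the ring and that hydrogen, would help separate the two, and piperidin-1-yl would test a larger ring.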